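The compounds below may be only part of what the source reports. "The series", "measured", "known", "first", "only" and "open" are said of these compounds alone.

Compound 1 `CC1CN(C(=O)c2ccc(-c3ccc(NC(=O)Nc4ccc(Cl)c(C(F)(F)F)c4)cc3)cc2)CC(C)O1` | > 50000 nM (a limit)
Compound 2 `O=C(/C=C/c1ccc(NC(=O)Nc2ccc(Cl)c(C(F)(F)F)c2)cc1)NC1CCC1` | 15400 nM

In a functional assay on A-375 cells (Homo sapiens) for inhibition, read by MTT assay, with a stated time of 120 h (a higher number here means a weaker inhibitor, a lower number a stronger inhibitor), compound 1 gives > 50000 nM as a limit of the assay, not a number. Among the compounds with values here, compound 2, at 15400 nM in this assay, therefore holds the only actual number so far. Compound 3 `O=C(CCc1ccc(NC(=O)Nc2ccc(Cl)c(C(F)(F)F)c2)cc1)NC1CCC1` carries 2-(cyclobutylcarbamoyl)ethyl in place of the 2-(cyclobutylcarbamoyl)ethenyl of compound 2 on an aromatic carbon (see 2-(cyclobutylcarbamoyl)ethyl in place of 2-(cyclobutylcarbamoyl)ethenyl on an aromatic carbon for the count). Within the data shown here, no measured step covers this change, so no shift beyond the scatter is expected in this assay, and the estimated step is small (see a 1.2-fold higher number from compound 2 to compound 3 (0.07 log units; within the scatter) for its size). Compound 3 is estimated at 18000 nM (expected range 7000 nM to 50000 nM).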

Compound 3, half-maximal inhibitory concentration: > 50000 nM
Compound 3 gave a limit, no number; the forecaster's own chance of this, stated with the estimate: 25%; middle value at least 2.7-fold (0.44 log units) away from the limit.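

Replacing 2-(cyclobutylcarbamoyl)ethenyl with 2-(cyclobutylcarbamoyl)ethyl, on an aromatic carbon para to a large group, is the first single-place change shown, and in this assay it gives an at least 3.2-fold higher number from compound 2 to compound 3 (0.51 log units; beyond the scatter). This position therefore does not tolerate the loss of that double bond without a shift beyond the scatter. Compound 3 gives a limit and not a number, so the full size of the step stays unknown: the limit of > 50000 nM in this assay, at which 2 of the 3 values shown sit.

On these data alone, whether an amine or a carboxylic acid in place of the cyclobutyl ring would lower the number of compound 2 stays open. So does the effect of a longer chain at this position.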